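The source may report more compounds than this note shows. Statements on the series, on what has been measured and on what is new or still open speak of the compounds shown alone.

In an assay on microsomes from brain for inhibition of Fatty-acid amide hydrolase 1 (Rattus norvegicus), read by fluorescence and HPLC, with a stated time of 60 min (a lower number here means a stronger inhibitor, a higher number a weaker inhibitor), three compounds have been measured. Compound 1 `CCCCCCCCc1ccc(OCC(=O)Cn2nnnc2-c2ccc(Cl)cc2)cc1` gives 130 nM, compound 2 `CCCCCCCCc1ccc(OCC(=O)Cn2nnnc2-c2cccc(Cl)c2)cc1` gives 360 nM, and compound 3 `CCCCCCCCc1ccc(OCC(=O)Cn2nnnc2-c2cccs2)cc1` gives 55 nM, the lowest of the three; its steps are a 2.4-fold lower number from compound 1 to compound 3 (0.37 log units; beyond the scatter) and a 6.5-fold lower number from compound 2 to compound 3 (0.82 log units; beyond the scatter).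

Compound 4 `CCCCCCCCc1ccc(OCC(=O)Cn2nnnc2-c2ccc(C(=O)O)cc2)cc1` differs from compound 3 by 4-carboxyphenyl in place of thiophen-2-yl on an aromatic carbon. The two steps that bear on this change, a 2.4-fold lower number from compound 1 to compound 3 (0.37 log units; beyond the scatter) and a 6.5-fold lower number from compound 2 to compound 3 (0.82 log units; beyond the scatter), both show that swapping the thiophen-2-yl for a six-membered ring raised the number modestly. No 4-carboxyphenyl has been measured at this place, so the size is uncertain, but a modest rise is the likeliest outcome. Compound 4 is therefore expected to give about 400 nM, within 100 nM to 1600 nM, as the expected step of a 7.3-fold higher number from compound 3 to compound 4 (0.86 log units; beyond the scatter).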

Compound 4, half-maximal inhibitory concentration: 3400 nM
Compound 4: middle estimate off by 8.5-fold (0.93 log units), on the low side, outside the stated range (above it).
By their numbers in this assay, from the lowest: compound 3; then compound 1; then compound 2; then compound 4.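

Swapping chloro for carboxy on the six-membered ring raises the number far more (a 26-fold higher number from compound 1 to compound 4 (1.42 log units; beyond the scatter)) than the earlier ring changes did, so the group carried by this ring can matter more than the ring itself. The 4-carboxyphenyl group gives the weakest inhibitor of the four in this assay (a 9.4-fold higher number from compound 2 to compound 4 (0.98 log units; beyond the scatter); a 62-fold higher number from compound 3 to compound 4 (1.79 log units; beyond the scatter)). Nothing measured here gives a reason for this rise.

As far as these compounds go, whether the carboxylic acid itself is what matters stays open, and a methyl ester or primary amide in its place would test that. Also open, from the compounds shown here alone, is how a 3-carboxyphenyl group, or a carboxylic acid on thiophen-2-yl, would behave.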